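Thiophen-3-yl in place of thiophen-2-yl on the shared core

The source may hold more compounds than are shown below. What is called first, only, known or untested is meant among the compounds shown, and "the series" means these compounds.

Measured in a functional assay on K562 cells (Homo sapiens), read by MTT assay, with a stated time of 72 h; on this read-out higher numbers stand for weaker inhibition and lower numbers for stronger inhibition:
- compound 1 `CSc1ncnc2c1c(-c1ccsc1)cn2[C@@H]1O[C@H](CO)[C@@H](O)[C@H]1O`: 450 nM
- compound 2 `CNc1ncnc2c1c(-c1ccco1)cn2[C@@H]1O[C@H](CO)[C@@H](O)[C@H]1O`: 220 nM
- compound 3 `CNc1ncnc2c1c(-c1cccs1)cn2[C@@H]1O[C@H](CO)[C@@H](O)[C@H]1O`: > 20000 nM, a limit

Compound 3 gives no number, and its reading of > 20000 nM is a limit of the assay. It stands at the limit of > 20000 nM in this assay, at which 1 of the 3 values shown sits. Compound 4 `CNc1ncnc2c1c(-c1ccsc1)cn2[C@@H]1O[C@H](CO)[C@@H](O)[C@H]1O` keeps everything in compound 3 except one group, with thiophen-3-yl in place of thiophen-2-yl on an aromatic carbon.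

Going by the values given here, one measured step bears directly on this place, namely an at least 90-fold higher number from compound 2 to compound 3 (1.95 log units; beyond the scatter). That large step shows that in this assay the read-out can respond strongly to the group at this place. Compound 1, which also carries thiophen-3-yl but differs elsewhere, gives 450 nM. On that basis a large step is expected, in the direction of a lower number and stronger inhibition, and the estimated size is an at least 20-fold lower number from compound 3 to compound 4 (1.30 log units; beyond the scatter). For compound 4 the expected value is 1000 nM, with an estimated range from 150 nM to 12000 nM.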

Compound 4, half-maximal inhibitory concentration: > 20000 nM
Compound 4 was reported as a limit; the forecaster's own chance of this, stated with the estimate: 20%; at least 20-fold (1.30 log units) between middle value and limit.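

In this assay, thiophen-3-yl at this place does not recover the inhibition seen with furan-2-yl, with an at least 90-fold higher number from compound 2 to compound 4 (1.95 log units; beyond the scatter); the step between compound 3 and compound 4 cannot be read, as both readings are limits. The other place of change now shows its weight too: methylamino in place of methylsulfanyl, with thiophen-3-yl kept, gives an at least 44-fold higher number from compound 1 to compound 4 (1.64 log units; beyond the scatter), so the read-out answers to that group as well. With methylamino on the shared core, thiophen-2-yl and thiophen-3-yl now end at the same limit: the limit of > 20000 nM in this assay, at which 2 of the 4 values shown sit.

The compounds shown leave open whether these two groups differ at all with methylamino, and how thiophen-2-yl or furan-2-yl behaves with methylsulfanyl. They also leave open whether furan-3-yl or phenyl at this place would keep inhibition alongside methylamino.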